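This account rests on a few compounds, and the source may have more. Where it says the series, first, only, none or still open, it means among the compounds named here.

Compound 3 `COc1cc(-c2cnn3cc(OC)c(C(C)(C)O)nc23)ccn1` gives 92% in an ADME assay on microsomes from liver (Rattus norvegicus) for metabolic stability, with a stated time of 60 min, tested at 1 uM (on this read-out lower numbers stand for a less stable compound and higher numbers for a more stable compound), the highest of the three numbers; compound 1 `Cn1cc(-c2nc3c(-c4ccnc(OC5CC5)c4)cnn3cc2OCC(C)(C)O)cn1` gives 81% and compound 2 `COc1cc(-c2cnn3cc(OC)c(C(C)C)nc23)ccn1` gives 14%. Among the measured compounds shown here, the single measured step, a number 78 percentage points higher from compound 2 to compound 3 (beyond the scatter), was large and came from adding the hydroxy group. The present change removes it along with the whole substituent: in compound 4 `COc1cc(-c2cnn3cc(OC)c(-c4cnn(C)c4)nc23)ccn1` the change is 1-methyl-1H-pyrazol-4-yl in place of 1-hydroxy-1-methylethyl on an aromatic carbon. For the measured compounds named here, no measured step covers this exchange directly; compound 1 carries the entering group on a different core and gives 81%. A drop in this assay is therefore expected for compound 4, a number 37 percentage points lower from compound 3 to compound 4 (beyond the scatter), smaller than a number 78 percentage points higher from compound 2 to compound 3 (beyond the scatter) and with wide uncertainty. Compound 4 is expected to give 55%, within 25% to 85%.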

Compound 4, percent of the compound remaining: 56%
For compound 4 the middle estimate is 1 percentage points below the measured one, and the stated range covers the measured number.
By their numbers in this assay, from the lowest: compound 2; then compound 4; then compound 1; then compound 3.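

In this assay, the 1-methyl-1H-pyrazol-4-yl group on this aromatic carbon gives an intermediate result: a number 36 percentage points lower from compound 3 to compound 4 (beyond the scatter) and a number 42 percentage points higher from compound 2 to compound 4 (beyond the scatter) on the shared core. A hydroxy group is therefore not needed at this position to stand clear of isopropyl, although 1-hydroxy-1-methylethyl remains the best of the three groups here. Nothing available explains this order. Still open, from the compounds shown here alone, is how a morpholine or a hydroxymethyl group would read on this carbon, and whether the order of the groups holds on the core of compound 1.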